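The source may hold more compounds than are shown below. What is called first, only, known or untested is meant among the compounds shown, and "the series" means these compounds.

Going by the values given here, compound 2 `O=C(NCc1ccncc1)Nc1ccc(S(=O)(=O)NCc2ccccc2)cc1` gives 102 nM in an assay on isolated protein for activation of Nicotinamide phosphoribosyltransferase (Homo sapiens) (a lower number here means that less compound is needed, a higher number that more compound is needed for the effect), the lowest of the two numbers known so far. Compound 1 `O=C(NCc1ccncc1)Nc1ccc(S(=O)(=O)N2CC3CCC(C2)O3)cc1` gives 279 nM in this assay, and the step of a 2.7-fold lower number from compound 1 to compound 2 (0.44 log units; beyond the scatter) shows that exchanging the group on the sulfonyl sulfur moved the number beyond the scatter. Compound 3 `CN(C)S(=O)(=O)c1ccc(NC(=O)NCc2ccncc2)cc1` changes that same position: dimethylamino in place of benzylamino on a sulfonyl sulfur. Among the compounds with values here, only that one step bears on this change, and it is modest, so a step in this assay of similar size is expected, most likely towards a higher number as the aromatic ring leaves; the estimated step is a 2.5-fold higher number from compound 2 to compound 3 (0.39 log units; beyond the scatter). Compound 3 is expected at 250 nM, between 100 nM and 700 nM.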

Compound 3, half-maximal effective concentration: 3110 nM
For compound 3 the middle estimate is 12-fold (1.09 log units) below the measured one; measured number above the stated range.
By their numbers in this assay, from the lowest: compound 2; then compound 1; then compound 3.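

In this assay, the group on the sulfonyl sulfur matters more than the first two compounds showed: a 30-fold higher number from compound 2 to compound 3 (1.48 log units; beyond the scatter) and an 11-fold higher number from compound 1 to compound 3 (1.05 log units; beyond the scatter) are both large. Dimethylamino, with the fewest heavy atoms, falls well behind both bigger groups, even though only one of those carries an aromatic ring. No measurement here explains this. Still open, going by these compounds, is whether size, the ring or the hydrogen on the nitrogen counts most. Methylamino, which keeps that hydrogen without a ring, and N-methylbenzylamino, which keeps the ring without it, would help separate these.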